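Compound 1 to Compound 4: a 2-Methylphenyl Enters

A few compounds are considered here, and "the series" means these few. Any claim that something is new, unique, unknown or untested is made for them only; others in the source may bear on it.

Compound 1 `CCCn1cc(C(N)=O)c2c(N)ncnc21` — 100000 nM
Compound 2 `CCCn1cc(C(=N)S)c2c(N)ncnc21` — 17000 nM
Compound 3 `Cc1ccc(Cn2cc(C#N)c3c(N)ncnc32)cc1` — > 100000 nM, a limit rather than a number

In a functional assay on KB cells (Homo sapiens) for cytotoxicity (on this read-out higher numbers stand for weaker inhibition and lower numbers for stronger inhibition), compound 1 gives 100000 nM, the highest of the two numbers shown. Compound 2 stands nearest, with a 5.9-fold lower number from compound 1 to compound 2 (0.77 log units; beyond the scatter). In this assay compound 3 sits at the limit of > 100000 nM in this assay, at which 1 of the 3 values shown sits. Compound 4 `Cc1ccccc1Cn1cc(C(N)=O)c2c(N)ncnc21` is not yet measured; it differs from compound 1 by 2-methylphenyl in place of ethyl on a saturated chain carbon bound to an aromatic nitrogen. Going by the values given here, no measured step changes this position: the step from compound 1 to compound 2 alters a group on an aromatic carbon, and compound 3 differs from compound 4 in more than one place. With nothing bearing directly on the change, no step beyond the scatter is expected in this assay. Compound 4 is therefore estimated at 100000 nM, between 30000 nM and 300000 nM. That corresponds to an expected no change at the digits printed from compound 1 to compound 4 (within the scatter).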

Compound 4, half-maximal inhibitory concentration: > 100000 nM
Compound 4: only a limit was reported; the forecaster's own chance of this, stated with the estimate: 50%; the middle value sits exactly at the limit.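

In this assay compound 4 reads > 100000 nM, which is a limit and not a number: the limit of > 100000 nM in this assay, at which 2 of the 4 values shown sit. With 2-methylphenyl in place of ethyl on a saturated chain carbon bound to an aromatic nitrogen, the result is a number no lower from compound 1 to compound 4 (the limit leaves the size open). Going by these compounds alone, this is the first measured change at this position, and it brings no stronger inhibition.

Going by these compounds, how weak compound 4 actually is stays open. So does whether a longer chain or an amine at this position would give a lower number.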